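The source may hold more compounds than are shown below. What is called first, only, known or untested is meant among the compounds shown, and "the series" means these compounds.

Compound 2 `CCCCCCCCCCCC(=O)O[C@H]1[C@@H](O[C@]2(COC(C)=O)O[C@H](CO)[C@@H](O)[C@@H]2O)O[C@H](CO)[C@@H](O)[C@@H]1OCC(C)C` stands second highest of three numbers in a functional assay on the whole organism (Ear, strain NIH) for inhibition, with Mus musculus as the target (a higher number here means a weaker inhibitor, a lower number a stronger inhibitor), where compound 2 gives 340 nM. Compound 1 `CCCCCCCCCCCC(=O)O[C@H]1[C@@H](O[C@]2(COC(C)=O)O[C@H](CO)[C@@H](O)[C@@H]2OCC(C)C)O[C@H](CO)[C@@H](O)[C@@H]1OCC(C)C` gives 260 nM, and compound 3 `C=C1[C@H](O)C[C@H]2C(C)(C)CCC[C@]2(C)[C@H]1C[C@@H](O)/C(C)=C/CO` gives 630 nM; both lie within the scatter of compound 2. For the measured compounds named here, the only measured step, a 1.3-fold higher number from compound 1 to compound 2 (0.12 log units; within the scatter), put hydrogen in place of isobutyl on an oxygen on a saturated carbon and stayed within the scatter. Compound 4 `CCCCCCCCCCCC(=O)O[C@H]1[C@@H](O[C@]2(CO)O[C@H](CO)[C@@H](O)[C@@H]2O)O[C@H](CO)[C@@H](O)[C@@H]1OCC(C)C` differs from compound 2 by hydrogen in place of acetyl on an oxygen on a saturated carbon, again a hydrogen entering on an oxygen on a saturated carbon, so a comparable outcome is expected in this assay, namely a 1.2-fold higher number from compound 2 to compound 4 (0.07 log units; within the scatter), no step beyond the scatter. The value of compound 4 is therefore estimated at 400 nM, with a range from 200 nM to 800 nM.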

Compound 4, half-maximal inhibitory concentration: 240 nM
The estimate for compound 4 lay 1.7-fold (0.22 log units) above the measured number, and the stated range covers the measured number.
By their numbers in this assay, from the lowest: compounds 4, 1, 2 and 3 (each within the scatter of the next, the first and the last beyond it).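

Acetoxymethyl to hydroxymethyl gave a 1.4-fold lower number from compound 2 to compound 4 (0.15 log units; within the scatter) in this assay, so the number stays in the same range without the acetyl on this oxygen. Together with the earlier step at an isobutyl oxygen, that makes two changes to hydrogen on an oxygen on a saturated carbon that stay within the scatter. Nothing given here explains why either change leaves the number in place. Still open, as far as these compounds go, is whether an amine or a carboxylic acid in place of this hydroxy would move the number beyond the scatter. So is whether hydrogen in place of the remaining isobutyl would do so.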